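A few compounds are considered here, and "the series" means these few. Any claim that something is new, unique, unknown or untested is made for them only; others in the source may bear on it.

In an assay on isolated protein for inhibition of Discoidin domain-containing receptor 2 (Homo sapiens), read by ELISA, with a stated time of 60 min (a lower number here means a stronger inhibitor, a higher number a weaker inhibitor), compound 1 `Cc1ccc(C(=O)Nc2cccc(CN3CCN(C)CC3)c2)cc1-c1ccc2cn[nH]c2c1` gives 75.9 nM, and compound 2 `CCn1cc(-c2n[nH]c3cc(-c4cc(C(=O)Nc5cccc(C(F)(F)F)c5)ccc4C)ccc23)cn1` gives 2.6 nM. Compound 2 thus stands at the lower of the two numbers, and its gap to compound 1 lies beyond the usual scatter. Compound 3 `Cc1ccc(C(=O)Nc2cccc(C(F)(F)F)c2)cc1-c1ccc2c(-c3cnn(C4CCN(C)CC4)c3)n[nH]c2c1` has not yet been measured in this assay. It differs from compound 2 in one place: 1-methylpiperidin-4-yl in place of ethyl on an aromatic nitrogen, so that the 1-ethyl-1H-pyrazol-4-yl group of compound 2 becomes a 1-(1-methylpiperidin-4-yl)-1H-pyrazol-4-yl group in compound 3. For the measured compounds named here, no measured pair shows the effect of such a change, so any expectation for compound 3 rests on the value of compound 2 alone. The step of a 1.3-fold higher number from compound 2 to compound 3 (0.13 log units; within the scatter) is expected to be small, not clearly beyond the scatter in either direction. Compound 3 is therefore estimated to give 3.5 nM in this assay, with a range from 1 nM to 12 nM.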

Compound 3, half-maximal inhibitory concentration: 3.8 nM
Beside the measured number, compound 3's estimate is 1.1-fold (0.04 log units) below it; the measured number falls inside the stated range.
By their numbers in this assay, from the lowest: compounds 2 and 3 (each within the scatter of the next); then compound 1.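

In this assay the change from ethyl to 1-methylpiperidin-4-yl on the aromatic nitrogen is a 1.5-fold higher number from compound 2 to compound 3 (0.16 log units; within the scatter) and so leaves the number in place. For the compounds shown here, this position, two ring bonds from the ring atom that bears a large group, therefore takes a six-membered non-aromatic ring with one hetero atom as well as ethyl, something the earlier compounds could not show. Nothing available accounts for why the number holds across this change.

The compounds shown leave open what a carboxylic acid, a longer chain ending in a hydroxyl group, or a cyclohexyl ring would give on the same aromatic nitrogen. They also leave open whether the ring nitrogen of the piperidine or its methyl group matters to the number at all.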